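The source may report more compounds than this note shows. Statements on the series, on what has been measured and on what is new or still open speak of the compounds shown alone.

Measured so far in a physicochemical assay for solubility, read by LC-MS, in phosphate buffer, with a stated time of 24 h, at pH 7.4; a higher number here means a more soluble compound, a lower number a less soluble compound:
- Compound 1 `CN(c1ncco1)c1cnc(NCc2c(F)ccc3c2CCO3)n2cnnc12`: 67000 nM
- Compound 2 `O=C1c2ccccc2CN1c1cnc(NCc2c(F)ccc3c2CCO3)n2cnnc12`: 4000 nM

Of these two numbers, the lower belongs to compound 2, at 4000 nM. Compound 3 `Fc1ccc2c(c1CNc1ncc(Oc3ccccc3)c3nncn13)CCO2` shares the core but has not yet been measured in this assay. Its difference from compound 2 is this: a group of 7 heavy atoms (6 carbon, 1 oxygen; one six-membered aromatic ring of carbon only) in place of a group of 10 heavy atoms (8 carbon, 1 nitrogen, 1 oxygen; one five-membered non-aromatic ring with 1 hetero atom, one six-membered aromatic ring of carbon only), on an aromatic carbon. Phenoxy thus sits on the aromatic carbon that carries the varied group in compounds 1 and 2.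

Going by the values given here, only one measured step bears on this change, a large one at that same carbon: a 17-fold lower number from compound 1 to compound 2 (1.22 log units; beyond the scatter). The group of compound 3 keeps a six-membered aromatic ring of carbon only, as the group of compound 2 does, and has no five-membered aromatic ring with 2 hetero atoms, unlike compound 1. With a single step to go on, compound 3 is therefore expected to lie much closer to compound 2, at 4000 nM, than to compound 1, at 67000 nM. The expected change is small and upward, possibly within the scatter: a 1.5-fold higher number from compound 2 to compound 3 (0.18 log units; within the scatter). For compound 3 the estimated value is 6000 nM, with an expected range of 1500 nM to 24000 nM.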

Compound 3, solubility: 8000 nM
For compound 3 the middle estimate is 1.3-fold (0.12 log units) below the measured one; measured number inside the range.
By their numbers in this assay, from the lowest: compounds 2 and 3 (each within the scatter of the next); then compound 1.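

In this assay, phenoxy on this aromatic carbon can't be separated from the group of compound 2: a 2.0-fold higher number from compound 2 to compound 3 (0.30 log units; within the scatter), so a five-membered non-aromatic ring is not needed for a value in this range. Set against methyl(1,3-oxazol-2-yl)amino, phenoxy gives an 8.4-fold lower number from compound 1 to compound 3 (0.92 log units; beyond the scatter), which shows that the drop first seen with compound 2 is not tied to that one group and that the count of heavy atoms alone does not account for it, as the groups of compound 1 and compound 3 each hold 7. Nothing available on these compounds gives a reason for either step.

The three compounds leave open whether the higher number of compound 1 goes with its five-membered aromatic ring with 2 hetero atoms, with the amine nitrogen that joins the group to the core, or with the absence of a six-membered aromatic ring of carbon only, as these features change together here. A dimethylamino group or a pyridyloxy group on the same carbon would help to pull these features apart.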